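Swapping 2-bromophenyl for 2,3-dichlorophenyl in a level series

The compounds below may be only part of what the source reports. "The series", "measured", "known", "first", "only" and "open" are said of these compounds alone.

Measured in a functional assay on B16-F10 cells (Mus musculus) for cytotoxicity; on this read-out lower numbers stand for stronger inhibition and higher numbers for weaker inhibition:
- Compound 1 `O=c1oc2ccccc2c2nc3c(ccc4cc[nH]c43)c(-c3cccc(Br)c3)c12`: 70700 nM
- Compound 2 `O=c1oc2ccccc2c2nc3c(ccc4cc[nH]c43)c(-c3ccc([N+](=O)[O-])cc3)c12`: 70700 nM
- Compound 3 `O=c1oc2ccccc2c2nc3c(ccc4cc[nH]c43)c(-c3ccccc3Br)c12`: 70700 nM

Compound 3 stands level with compounds 1 and 2 on these numbers. The unmeasured compound 4 `O=c1oc2ccccc2c2nc3c(ccc4cc[nH]c43)c(-c3cccc(Cl)c3Cl)c12` differs from it as follows: 2,3-dichlorophenyl in place of 2-bromophenyl on an aromatic carbon. In short, it has 2,3-dichlorophenyl in place of 2-bromophenyl on an aromatic carbon. Three measured swaps of the group on that carbon bear on this: no change at the digits printed from compound 1 to compound 2 (within the scatter), no change at the digits printed from compound 1 to compound 3 (within the scatter) and no change at the digits printed from compound 2 to compound 3 (within the scatter). None moved the value, so no step beyond the scatter is expected in this assay, in either direction. None of these compounds carries the 2,3-dichlorophenyl group, however, so this remains an extrapolation. The expected step is no change at the digits printed from compound 3 to compound 4 (within the scatter). For compound 4 the estimated value is 70700 nM, with an expected range from 35000 nM to 100000 nM.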

Compound 4, half-maximal inhibitory concentration: 70700 nM
Estimate against measurement, compound 4: no gap at the digits printed, within the range that was stated.
By their numbers in this assay, from the lowest: compounds 1, 2, 3 and 4 (each within the scatter of the next).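

In this assay the 2,3-dichlorophenyl group gives no change at the digits printed from compound 3 to compound 4 (within the scatter) and no change at the digits printed from compound 2 to compound 4 (within the scatter) and also no change at the digits printed from compound 1 to compound 4 (within the scatter) in this series. Going by these compounds alone, two chlorine atoms on the phenyl ring, a pattern absent from the earlier compounds, therefore sit level with a single bromine or a nitro group on this carbon. No evidence is available to explain this flat result. All four compounds carry a substituted phenyl ring here. Still open, on these data alone, is whether a phenyl ring bearing an amine or a carboxylic acid, or a longer chain in place of the ring, would shift the value.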